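The compounds below may be only part of what the source reports. "The series", "measured", "known", "first", "only" and "open" are said of these compounds alone.

Three compounds built on one shared core were tested in an ADME assay on BJ cells (Homo sapiens) for cytotoxicity, read by CellTiter-Glo and resazurin assay, with a stated time of 72 h; on this read-out lower numbers stand for an effect already at smaller amounts and higher numbers for an effect only at larger amounts of compound. Compound 1 `CC(C)N(Cc1cccc(OCCCCCC(=O)O)c1)C(=O)c1ccc(-c2ccc3c(c2)OCCO3)cc1` ends its chain in a free carboxylic acid. In this assay compound 1 gives only a limit, > 21900 nM, and not a number. Compound 2 `CC(C)N(Cc1cccc(OCCCCCC(=O)O)c1)C(=O)c1ccc(-c2ccc3cc[nH]c3c2)cc1` differs from compound 1 by 1H-indol-6-yl in place of 2,3-dihydro-1,4-benzodioxin-6-yl on an aromatic carbon. In this assay compound 2 likewise gives only a limit, > 26000 nM. The size of the step that the two limits leave unreadable from compound 1 to compound 2 cannot be read, because compound 1 sits at the limit of > 21900 nM in this assay, at which 1 of the 3 values shown sits. The same holds because compound 2 sits at the limit of > 26000 nM in this assay, at which 1 of the 3 values shown sits.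

Compound 3 `CCOC(=O)CCCCCOc1cccc(CN(C(=O)c2ccc(-c3ccc4c(c3)OCCO4)cc2)C(C)C)c1` differs from compound 1 by ethyl in place of hydrogen on an oxygen next to a carbonyl group; this is how the two cores of the pair differ. In this assay compound 3 again gives only a limit, > 24400 nM. The step that the two limits leave unreadable from compound 1 to compound 3 stays unreadable because compound 3 sits at the limit of > 24400 nM in this assay, at which 1 of the 3 values shown sits.

Compound 4 `CCOC(=O)CCCCCOc1cccc(CN(C(=O)c2ccc(-c3ccc4cc[nH]c4c3)cc2)C(C)C)c1` has not been measured. It differs from compound 3 by 1H-indol-6-yl in place of 2,3-dihydro-1,4-benzodioxin-6-yl on an aromatic carbon, the same change made from compound 1 to compound 2, at the same place. Going by the values given here, since neither partner of that earlier pair gave a number, the expected step that the limit leaves unreadable from compound 3 to compound 4 in this assay rests only on the observation that every compound so far stayed at a limit. Compound 4 is therefore expected near 30000 nM in this assay, most likely again as a limit, within an estimated range from 15000 nM to 100000 nM.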

Compound 4, half-maximal effective concentration: > 26000 nM
Compound 4 gave a limit, no number; the forecaster's own chance of this, stated with the estimate: 85%; the middle value is on the limit's open side.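

Compound 4 also gives only a limit and not a number in this assay, so neither the step from compound 3 to compound 4 nor the step from compound 2 to compound 4 can be read. The four compounds leave open at what concentration any of them would show an effect, and whether either 1H-indol-6-yl or ethyl in these places changes that concentration.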